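Widening the aryl ether on compound 3

The compounds below may be only part of what the source reports. "The series", "measured", "known", "first", "only" and "open" are said of these compounds alone.

Compound 1 `COC(=O)c1cc(OCC(=O)[C@H](CC(=O)O)NC(=O)[C@@H](NC(=O)COc2cccc3ccccc23)C(C)C)no1` anchors the set: in a functional assay on Jurkat cells (Homo sapiens) for inhibition (on this read-out lower numbers stand for stronger inhibition and higher numbers for weaker inhibition), compound 1 gives 71000 nM. Compound 2 `CC(C)[C@H](NC(=O)COc1cccc2ccccc12)C(=O)N[C@@H](CC(=O)O)C(=O)COc1nc2ccccc2[nH]1` carries 1H-benzimidazol-2-yl in place of 5-(methoxycarbonyl)-1,2-oxazol-3-yl on an oxygen on a saturated carbon, and in this assay compound 2 reaches only the limit > 200000 nM. Compound 3 `CC(C)[C@H](NC(=O)COc1cccc2ccccc12)C(=O)N[C@@H](CC(=O)O)C(=O)COc1ccccn1` carries pyridin-2-yl at that same oxygen, and in this assay compound 3 likewise reaches only the limit > 200000 nM. Compound 3 therefore stands at the weak end of what has been measured, sharing that ceiling with compound 2, so the step that the two limits leave unreadable from compound 2 to compound 3 cannot be read. Both departures from compound 1 were of similar kind, an at least 2.8-fold higher number from compound 1 to compound 2 (0.44 log units; beyond the scatter) and an at least 2.8-fold higher number from compound 1 to compound 3 (0.44 log units; beyond the scatter), and the limit of > 200000 nM in this assay, at which 2 of the 3 values shown sit, fixes how much of them can be stated.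

Compound 4 `CC(C)[C@H](NC(=O)COc1cccc2ccccc12)C(=O)N[C@@H](CC(=O)O)C(=O)COc1ccc2ccccc2n1` differs from compound 3 by quinolin-2-yl in place of pyridin-2-yl on an oxygen on a saturated carbon. Going by the values given here, no measured step swaps one aryl group on this oxygen for a larger one of the same family, so the measured steps bear on it only indirectly: every exchange at this position so far has carried the number to the limit. The account thus expects no movement beyond the scatter, with compound 4 expected to give 200000 nM, between 60000 nM and 500000 nM, which is an expected step of a number no higher from compound 3 to compound 4 (the limit leaves the size open).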

Compound 4, half-maximal inhibitory concentration: > 200000 nM
Compound 4: a limit, no number; the forecaster's own chance of this, stated with the estimate: 70%; the middle value sits exactly at the limit.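

In this assay compound 4 gives > 200000 nM as well, which is a limit of the assay and not a number. What this adds is that the second six-membered aromatic ring, of carbon only, in quinolin-2-yl does not bring the read-out back under that limit at this oxygen on a saturated carbon, so a larger aryl group here does not restore the level of compound 1, and the exchange shows an at least 2.8-fold higher number from compound 1 to compound 4 (0.44 log units; beyond the scatter) as the third replacement of 5-(methoxycarbonyl)-1,2-oxazol-3-yl to end this way, with compound 1 the only one of the set that gives a number. The steps from compound 2 and from compound 3 to compound 4 cannot be read, because all of these compounds sit at one limit: the limit of > 200000 nM in this assay, at which 3 of the 4 values shown sit.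

The compounds shown leave open whether the number of compound 1 rests on the 1,2-oxazol-3-yl ring or on its methoxycarbonyl group, and how far compound 2, compound 3 and compound 4 lie from one another beyond the limit. Also open, as far as these compounds go, is whether a carboxylic acid in place of that methoxycarbonyl group, or an amine on the quinolin-2-yl, would give a readable number.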